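Trimming compound 1 to the free acid

The source may report more compounds than this note shows. Statements on the series, on what has been measured and on what is new or still open speak of the compounds shown alone.

A series of three measured compounds shares a core in which an acrylic chain is attached to a pyridine bearing a bicyclic aryl group. Compound 1 `CC(C)[C@@H](NC(=O)/C=C/c1ccncc1-c1ccc2ccccc2c1)C(=O)O` carries a (1-carboxy-2-methylpropyl)amino group on its carbonyl carbon. In an assay on a protein complex for inhibition of CDK8/Cyclin C (Homo sapiens), with a stated time of 1 h, tested at 10 uM (a higher number here means more inhibition at the concentration tested (going by the name of the read-out), a lower number less inhibition), compound 1 gives 77%, the lowest of the three numbers. Compound 3 `CNC(=O)/C=C/c1ccncc1-c1ccc2[nH]ccc2c1` gives 100% in this assay, a gap beyond the scatter, and compound 2 `Cn1ccc2cc(-c3cnccc3/C=C/C(=O)O)ccc21` gives 102%, also beyond the scatter above compound 1. No pair among these three differs in a single place, so no single step is isolated by the measured set.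

Compound 4 `O=C(O)/C=C/c1ccncc1-c1ccc2ccccc2c1` is the compound under consideration. It differs from compound 1 in one place: hydroxy in place of (1-carboxy-2-methylpropyl)amino on a carbonyl carbon. Going by the values given here, no measured pair isolates this change, so the expectation rests on the general level of the series. Because compound 2 gives 102% as a free acid in this assay, the free acid of compound 4 is expected to sit higher than compound 1, and the step from compound 1 to compound 4 is estimated as a number 13 percentage points higher from compound 1 to compound 4 (beyond the scatter), a moderate rise. Compound 4 is therefore expected to give about 90% in this assay, with a plausible range from 70% to 105%.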

Compound 4, a percentage reported as inhibition, at one concentration (the size of the read-out at that concentration, not a potency): 102%
The estimate for compound 4 lay 12 percentage points below the measured number, and the stated range covers the measured number.
By their numbers in this assay, from the lowest: compound 1; then compounds 3, 2 and 4 (each within the scatter of the next).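

The step gives the series its first single change at this position: in this assay, hydroxy in place of (1-carboxy-2-methylpropyl)amino on a carbonyl carbon gives a number 25 percentage points higher from compound 1 to compound 4 (beyond the scatter). This shows that the read-out responds to what sits on this carbonyl carbon, and that the 8 heavy atoms and defined stereocentre of the departing group are not needed for compound 4 to reach 102% at the one concentration tested. Nothing measured here accounts for the size of this step.

Since the change removes the whole (1-carboxy-2-methylpropyl)amino group at once, the compounds shown do not separate the contributions of its amide nitrogen, its branched chain and its carboxylic acid. A plain amino group, or an aminoacetic acid chain without the branch, on the same carbonyl carbon of the core of compound 4 would begin to divide that step, while a single-concentration read-out leaves any difference in potency between compound 1 and compound 4 unresolved.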